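Alkyne aryl swap on a shared amide core

This account rests on a few compounds, and the source may have more. Where it says the series, first, only, none or still open, it means among the compounds named here.

Measured so far in a functional assay on HEK293 cells for positive allosteric modulation of metabotropic glutamate receptor 5 (Rattus norvegicus), read by fluorescence and calcium flux; on this read-out lower numbers stand for smaller maximal responses and higher numbers for larger maximal responses:
compound 1 `Cc1cccc(C#Cc2ccc(C(=O)N[C@H](C)C(C)(C)O)nc2)c1` gives 68.6%;
compound 2 `C[C@@H](NC(=O)c1ccc(C#Cc2ccncc2)cn1)C(C)(C)O` gives 66.6%.

Compound 2 holds the lower of the two numbers, yet its distance to compound 1 is within the scatter. Compound 3 `C[C@@H](NC(=O)c1ccc(C#Cc2ccc(F)cn2)cn1)C(C)(C)O` differs from compound 2 by 5-fluoropyridin-2-yl in place of pyridin-4-yl on a triple-bonded carbon. For the measured compounds named here, the only measured step, a number 2 percentage points lower from compound 1 to compound 2 (within the scatter), also exchanged the group on the triple-bonded carbon and stayed within the scatter; no step covers a fluorine-bearing ring at this place. The change is therefore expected to give no step beyond the scatter in this assay, that is a number 0.4 percentage points higher from compound 2 to compound 3 (within the scatter). For compound 3 the expected value is 67%, between 50% and 84%.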

Compound 3, largest response reached (reported as efficacy), in percent of the reference or control that the assay uses: 64.6%
For compound 3 the middle estimate is 2.4 percentage points above the measured one; low and high end bracket the measured number.
By their numbers in this assay, from the lowest: compounds 3, 2 and 1 (each within the scatter of the next).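

In this assay the first fluorine-bearing ring at this place gives a number 2 percentage points lower from compound 2 to compound 3 (within the scatter) and, set against the 3-methylphenyl group, a number 4 percentage points lower from compound 1 to compound 3 (within the scatter). The triple-bonded carbon therefore carries 3-methylphenyl, pyridin-4-yl or 5-fluoropyridin-2-yl with all three compounds within the scatter of one another. No evidence on hand bears on this result.

Open, on these data alone, is whether a group without an aromatic ring on the triple-bonded carbon, such as cyclohexyl or a longer alkyl chain, stays within the same scatter. Also open, as far as these compounds go, is how a carboxylic acid or an amine on the ring would read out.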